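The source may hold more compounds than are shown below. What is called first, only, known or untested is meant among the compounds shown, and "the series" means these compounds.

Working notes on the series, with the group on the amide carbonyl varied around a shared core. In an ADME assay on microsomes from liver (Homo sapiens) for metabolic stability, read by LC-MS, with a stated time of 30 min, tested at 1 uM (on this read-out higher numbers stand for a more stable compound and lower numbers for a less stable compound), compound 1 `O=C(NCc1ccc(S(=O)(=O)c2ccccc2)cc1)c1ccc2nccn2c1` gives 77% and compound 2 `O=C(NCc1ccc(S(=O)(=O)c2ccccc2)cc1)c1cn2ccnc2cn1` gives 87%. The two numbers cannot be told apart, so compound 2 stands level with compound 1 within the scatter.

Compound 3 `O=C(NCc1ccc(S(=O)(=O)c2ccccc2)cc1)c1cc2cnccc2[nH]1` is the next to be read. Its difference from compound 2 is a group of 9 heavy atoms (7 carbon, 2 nitrogen; one five-membered aromatic ring with 1 hetero atom, one six-membered aromatic ring with 1 hetero atom) in place of a group of 9 heavy atoms (6 carbon, 3 nitrogen; one five-membered aromatic ring with 2 hetero atoms, one six-membered aromatic ring with 2 hetero atoms), on a carbonyl carbon, on a carbonyl carbon whose other neighbours are: amide-type nitrogen.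

Going by the values given here, one measured step bears on this change, also an exchange of a group on a carbonyl carbon: a number 10 percentage points higher from compound 1 to compound 2 (within the scatter). That step stays within the scatter, but it is a single step and a different exchange, so it sets only a loose guide. With compound 2 at 87%, little room is left upward on this assay, and a small fall, no clear step beyond the scatter, is expected. The estimated change is a number 9 percentage points lower from compound 2 to compound 3 (within the scatter). The estimate for compound 3 is 78%, with an expected range of 58% to 92%.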

Compound 3, percent of the compound remaining: 75%
Compound 3: the middle estimate sits 3 percentage points above what was measured, and the stated range covers the measured number.
By their numbers in this assay, from the lowest: compounds 3, 1 and 2 (each within the scatter of the next, the first and the last beyond it).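

In this assay, an exchange on a carbonyl carbon whose other neighbours are: amide-type nitrogen now gives a step beyond the scatter, a modest one: a number 12 percentage points lower from compound 2 to compound 3 (beyond the scatter). The group that enters has 7 carbon and 2 nitrogen, with 1 hydrogen-bond donor and 1 hydrogen-bond acceptor, while the group that leaves has 6 carbon and 3 nitrogen, with 0 hydrogen-bond donors and 3 hydrogen-bond acceptors. Set against the group of compound 1, the same entering group stays within the scatter, a number 2 percentage points lower from compound 1 to compound 3 (within the scatter), so only compound 2 and compound 3 are separated at this position, and nothing at hand accounts for that separation.

The exchange from compound 2 to compound 3 alters the ring hetero atoms and the donor and acceptor counts together, so the compounds shown cannot assign the step to any one of these differences. Also open, going by these compounds, is how the read-out responds to a group outside these fused pairs on the same carbonyl carbon, such as a plain phenyl ring or an open-chain amine.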